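The source may hold more compounds than are shown below. What is called first, only, known or untested is meant among the compounds shown, and "the series" means these compounds.

In a functional assay on MCF7 cells (Homo sapiens) for inhibition, read by MTT assay, with a stated time of 72 h (on this read-out lower numbers stand for stronger inhibition and higher numbers for weaker inhibition), compound 1 `CCC(=O)O[C@@H](/C(C)=C/[C@@H](C)c1oc(CC)c(C)c(=O)c1C)[C@H](C)[C@@H](OC(=O)CC(C)C)[C@@H](C)c1oc([C@@H](C)[C@@H](O)CC)c(C)c(=O)c1C` gives 12000 nM, and compound 2 `CCc1oc([C@H](C)/C=C(\C)[C@H](OC(C)=O)[C@H](C)[C@@H](OC(=O)CC(C)C)[C@@H](C)c2oc([C@@H](C)[C@H](CC)OC(C)=O)c(C)c(=O)c2C)c(C)c(=O)c1C` gives 25000 nM. Compound 2 therefore holds the higher of the two numbers, which means the weaker inhibition, and its gap to compound 1 lies beyond the scatter.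

Compound 3 `CCC(=O)O[C@@H](/C(C)=C/[C@@H](C)c1oc(CC)c(C)c(=O)c1C)[C@H](C)[C@@H](OC(=O)CC(C)C)[C@@H](C)c1oc([C@@H](C)[C@H](CC)OC(C)=O)c(C)c(=O)c1C` is compound 2 with one change: methyl in place of hydrogen on a saturated chain carbon bound to a carbonyl carbon. This is methyl in place of hydrogen on a saturated chain carbon bound to a carbonyl carbon, so an acetoxy becomes a propanoyloxy. For the measured compounds named here, no measured pair shows this change on its own, so the data offer no direct guide to its effect.

It is a small edit, so no step beyond the scatter is expected in this assay, starting from compound 2 at 25000 nM. The estimated step of a 1.3-fold lower number from compound 2 to compound 3 (0.10 log units; within the scatter) stays within the scatter. For compound 3 the estimated value is 20000 nM, with an expected range of 9000 nM to 42000 nM.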

Compound 3, half-maximal inhibitory concentration: 4000 nM
The estimate for compound 3 lay 5.0-fold (0.70 log units) above the measured number; the measured number lies below the stated range.
By their numbers in this assay, from the lowest: compound 3; then compound 1; then compound 2.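

In this assay, for the compounds shown here, a single methyl in place of hydrogen on a saturated chain carbon bound to a carbonyl carbon, which turns an acetoxy into a propanoyloxy, gives a 6.3-fold lower number from compound 2 to compound 3 (0.80 log units; beyond the scatter), so this position responds to even a very small edit, something no earlier pair could show. Acetyl in place of hydrogen on an oxygen on a saturated carbon gives a 3.0-fold lower number from compound 1 to compound 3 (0.48 log units; beyond the scatter), so the stronger inhibition of compound 3 also depends on that oxygen carrying an acetyl rather than a bare hydrogen. Nothing available here explains either step.

Going by these compounds, it remains open whether a longer chain, such as a butanoyloxy, would continue this gain or reverse it. On these data alone, it is equally open whether an amide could stand in for the propanoyloxy ester and keep the effect.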